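From 5-carboxypyridin-3-yl to 4-aminophenyl: working notes

The source may report more compounds than this note shows. Statements on the series, on what has been measured and on what is new or still open speak of the compounds shown alone.

Measured in a physicochemical assay for solubility, read by LC-MS, using the shake flask method, measured as thermodynamic solubility, with a stated time of 24 h, at pH 6.5; a lower number here means a less soluble compound, a higher number a more soluble compound:
- Compound 1 `O=C(O)c1ccc(-n2cc(CO[C@H]3O[C@H](CO)[C@@H](O)[C@H](O)[C@@H]3O)nn2)cc1`: > 3000 ug/mL (a limit)
- Compound 2 `O=C(O)c1cncc(-n2cc(CO[C@H]3O[C@H](CO)[C@@H](O)[C@H](O)[C@@H]3O)nn2)c1`: > 3000 ug/mL (a limit)

Compound 2 stands only at a limit, > 3000 ug/mL. Both measured compounds share (the limit of > 3000 ug/mL in this assay, at which 2 of the 2 values shown sit). Among the compounds with values here, the one measured step, a step that the two limits leave unreadable from compound 1 to compound 2, gives no size to carry forward.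

Compound 3 `Nc1ccc(-n2cc(CO[C@H]3O[C@H](CO)[C@@H](O)[C@H](O)[C@@H]3O)nn2)cc1` carries 4-aminophenyl in place of 5-carboxypyridin-3-yl on an aromatic nitrogen. Within the data shown here, no measured step covers this change, so the expectation rests on the structural change alone. A downward move in this assay is expected, loosely estimated as an at least 2.0-fold lower number from compound 2 to compound 3 (0.30 log units; that floor lies within the scatter). For compound 3 the estimate is 1500 ug/mL, with an expected range of 400 ug/mL to 3000 ug/mL.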

Compound 3, solubility: > 2000 ug/mL
Compound 3: no number, only a limit (the forecaster's own chance of this, stated with the estimate: 30%); middle value at least 1.3-fold (0.12 log units) from the limit.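

In this assay compound 3 gives only a limit, > 2000 ug/mL. Within the data shown here, with compound 1 and compound 2 also at limits, no step among the three can be read. On these data alone, the true solubility of all three remains open.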